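The compounds below may be only part of what the source reports. "The series", "measured", "known", "first", "only" and "open" are said of these compounds alone.

Three compounds have so far been measured in a functional assay on MCF7 cells (Homo sapiens) for inhibition, read by sulforhodamine B assay, with a stated time of 72 h; a lower number here means a stronger inhibitor, a higher number a weaker inhibitor:

- compound 1, `CC(c1ccc(-c2ccccc2)c(F)c1)c1nnc2n1N=C(c1ccc(Cl)cc1Cl)CS2`, gives 7600 nM
- compound 2, `CC(C)Cc1ccc(C(C)c2nnc3n2N=C(c2ccc(F)cc2)CS3)cc1`, gives 8900 nM
- compound 3, `COc1ccc2cc(C(C)c3nnc4n3N=C(c3ccc(F)cc3)CS4)ccc2c1`, gives 15800 nM

Compound 2 stands at the second highest of these three numbers. Its nearest neighbour is compound 1 and its furthest is compound 3, yet both gaps lie within the usual scatter of repeated measurements, so the three numbers cannot be ranked against one another with any confidence.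

Compound 4, `CC(C)Cc1ccc(C(C)c2nnc3n2N=C(c2ccc(Cl)cc2Cl)CS3)cc1`, keeps everything in compound 2 except one part: 2,4-dichlorophenyl in place of 4-fluorophenyl on a carbon with a double bond to nitrogen. Going by the values given here, no measured pair shows exactly this exchange on an otherwise identical scaffold. Compound 1 does carry the 2,4-dichlorophenyl, but it also carries a different group on the other side of the shared core, so its value shows only what that whole compound does, not what this one swap does. With all three measured values so close together, the expected step from compound 2 to compound 4 in this assay is small, most likely within the scatter, with at most a slight lean toward a lower number. The expected value for compound 4 is 7000 nM, with a range from 3000 nM to 16000 nM, which corresponds to an expected step of a 1.3-fold lower number from compound 2 to compound 4 (0.10 log units; within the scatter).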

Compound 4, half-maximal inhibitory concentration: 11800 nM
The estimate for compound 4 lay 1.7-fold (0.23 log units) below the measured number; low and high end bracket the measured number.
By their numbers in this assay, from the lowest: compounds 1, 2, 4 and 3 (each within the scatter of the next, the first and the last beyond it).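

In this assay, the exchange of 4-fluorophenyl for 2,4-dichlorophenyl can now be read directly, with the rest of the molecule held fixed: a 1.3-fold higher number from compound 2 to compound 4 (0.12 log units; within the scatter). The earlier compounds shown here could not show this, since compound 1 differs from compound 2 in more than one place. For this one pair, then, a second halogen on the ring, chlorine in place of fluorine, and the extra heavy atom that comes with them together leave the number at this carbon with a double bond to nitrogen indistinguishable from the scatter of repeated measurements. Nothing available here explains the result or shows how either group acts at this position.

Going by these compounds, this is a single exchange on a single background, so it remains unknown whether the same swap would give as small a step with the different group that compound 3 carries on the other side of the shared core. On these data alone, it also remains open whether a more different group at this position, such as a phenyl ring bearing an amine or a carboxylic acid, or a longer alkyl chain in place of the ring, would move the number beyond the scatter.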